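Replacing an Oxygen Link with a Nitrogen Link

The source may hold more compounds than are shown below. What is called first, only, known or untested is meant among the compounds shown, and "the series" means these compounds.

Compound 2 `Cc1cc(Oc2cccc(Cl)c2)c(S(C)(=O)=O)cc1C(=O)N=C(N)N` carries a 3-chlorophenoxy group on the shared core. In a functional assay for inhibition of sodium/hydrogen exchanger (Oryctolagus cuniculus) (a higher number here means a weaker inhibitor, a lower number a stronger inhibitor), compound 2 gives 21 nM, a number that lies within the scatter of compound 1 `Cc1cc(OC(C)C)c(S(C)(=O)=O)cc1C(=O)N=C(N)N`, which gives 19 nM; the step of a 1.1-fold higher number from compound 1 to compound 2 (0.04 log units; within the scatter) bears this out. Compound 3 `Cc1cc(Nc2cccc(Cl)c2)c(S(C)(=O)=O)cc1C(=O)N=C(N)N` differs from compound 2 by (3-chlorophenyl)amino in place of 3-chlorophenoxy on an aromatic carbon. For the measured compounds named here, no measured step covers a change from 3-chlorophenoxy to (3-chlorophenyl)amino, so the only guide is that the two measured numbers sit close together. Compound 3 is therefore expected to show a 1.2-fold higher number from compound 2 to compound 3 (0.08 log units; within the scatter), a step not beyond the scatter. The estimate for compound 3 is 25 nM, with a range from 8 nM to 80 nM.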

Compound 3, half-maximal inhibitory concentration: 33 nM
For compound 3 the middle estimate is 1.3-fold (0.12 log units) below the measured one; the range from low to high includes it.
By their numbers in this assay, from the lowest: compounds 1, 2 and 3 (each within the scatter of the next).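

Exchanging the oxygen link for a nitrogen link, which adds a hydrogen-bond donor, gives a 1.6-fold higher number from compound 2 to compound 3 (0.20 log units; within the scatter) in this assay, so the two links cannot be told apart at this position. The (3-chlorophenyl)amino group also cannot be told apart from the isopropoxy group, with a 1.7-fold higher number from compound 1 to compound 3 (0.24 log units; within the scatter). Nothing available bears on the reason for this result.

Still open, on these data alone, is whether a sulfur or methylene link would also leave the number within the scatter. A methyl group on the nitrogen link, or an unsubstituted amine at this position, also remains untested among the compounds shown.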